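Trifluoromethyl for fluoro at a second place

The source may report more compounds than this note shows. Statements on the series, on what has been measured and on what is new or still open speak of the compounds shown alone.

Among the measured compounds shown here, in an ADME assay on cells (Hepatocyte, Mus musculus) for cytotoxicity, read by MTT assay, with a stated time of 24 h (on this read-out lower numbers stand for higher toxicity in this test and higher numbers for lower toxicity in this test), compound 2 `O=S(=O)(c1ccc(F)cc1)n1c(-c2cn(-c3ccccc3)nc2-c2ccc(F)cc2)nc2ccccc21` gives 174000 nM and stands highest of the two exact numbers so far. Compound 3 `O=S(=O)(c1ccc(C(F)(F)F)cc1)n1c(-c2cn(-c3ccccc3)nc2-c2ccc(F)cc2)nc2ccccc21` gives 55300 nM as the other exact number. Compound 1 `O=[N+]([O-])c1ccc(S(=O)(=O)n2c(-c3cn(-c4ccccc4)nc3-c3ccc(F)cc3)nc3ccccc32)cc1` gives > 300000 nM as a limit of the assay and not a number.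

Compound 4 `O=S(=O)(c1ccc(F)cc1)n1c(-c2cn(-c3ccccc3)nc2-c2ccc(C(F)(F)F)cc2)nc2ccccc21` differs from compound 2 by trifluoromethyl in place of fluoro on an aromatic carbon with trifluoromethyl in place of fluoro on an aromatic carbon, para to a large group, turning 4-fluorophenyl into 4-(trifluoromethyl)phenyl. For the measured compounds named here, the nearest guide is the same swap made at another place in the molecule, which gave a 3.1-fold lower number from compound 2 to compound 3 (0.50 log units; beyond the scatter) and is the only exact step available. The steps from compound 1 replace nitro and start from a limit, so they say little here. A single precedent at another place is thin evidence, but a lower number of similar size is expected. The step expected on that ground is a 2.5-fold lower number from compound 2 to compound 4 (0.40 log units; beyond the scatter) as an estimate. Compound 4 is estimated at 70000 nM with an expected range of 25000 nM to 200000 nM for the coming measurement.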

Compound 4, half-maximal cytotoxic concentration: 83300 nM
The estimate for compound 4 lay 1.2-fold (0.08 log units) below the measured number; low and high end bracket the measured number.
By their numbers in this assay, from the lowest: compounds 3 and 4 (each within the scatter of the next); then compound 2. At a limit, above all of these: compound 1.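

In this assay, changing 4-fluorophenyl to 4-(trifluoromethyl)phenyl gives a 2.1-fold lower number from compound 2 to compound 4 (0.32 log units; beyond the scatter) and so lowers the number at a second place in the molecule. Among the compounds shown here, until now the only exact precedent for this swap was a 3.1-fold lower number from compound 2 to compound 3 (0.50 log units; beyond the scatter) at another place, so the same change, made at either of two places on compound 2, now points the same way, and both steps are modest. Nothing measured in these compounds gives a reason for the lowering.

Going by these compounds, whether the lowering is tied to trifluoromethyl alone stays open, since an amine or a carboxylic acid on this ring could behave quite differently. On these data alone, it is also open what trifluoromethyl at both places at once would do to the number, since each compound here carries the swap at only one place.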